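The compounds below may be only part of what the source reports. "The series", "measured", "known", "first", "only" and "open" are said of these compounds alone.

Working notes on the series. Compound 1 `CCNC(=O)Nc1c(OCCCn2cnc(-c3ccccc3)c2)cccc1N(C)C` gives 870 nM in an assay for inhibition of acyl-CoA:cholesterol acyltransferase (Oryctolagus cuniculus), using microsomes; a higher number here means a weaker inhibitor, a lower number a stronger inhibitor. Compound 2 `CN(C)c1cccc(OCCCn2cnc(-c3ccccc3)c2)c1NC(=O)NC1CCCCC1` gives 73 nM in this assay, and compound 3 `CN(C)c1cccc(OCCCn2cnc(-c3ccccc3)c2)c1NC(=O)NC1CCCC1` gives 240 nM in this assay. Among these three numbers compound 3 stands second highest, with compound 2 nearest and compound 1 furthest. Every measured step concerns the group on the amide-type nitrogen: a 12-fold lower number from compound 1 to compound 2 (1.08 log units; beyond the scatter), a 3.6-fold lower number from compound 1 to compound 3 (0.56 log units; beyond the scatter) and a 3.3-fold higher number from compound 2 to compound 3 (0.52 log units; beyond the scatter). Compound 4 `CCCCCCNc1c(OCCCn2cnc(-c3ccccc3)c2)cccc1N(C)C` differs from compound 3 in a different place: hexyl in place of cyclopentylcarbamoyl on a nitrogen on an aromatic ring. For the measured compounds named here, none of the measured steps bears on this change; all three measured compounds retain a carbamoyl group on the nitrogen on the aromatic ring and vary only what sits on its amide-type nitrogen, so the data give no direct guide. With a group shared by every measured compound removed and replaced by hexyl, the expectation for compound 4 in this assay is a higher number, a 10-fold higher number from compound 3 to compound 4 (1.02 log units; beyond the scatter), held with little confidence. Compound 4 is therefore expected to give about 2500 nM in this assay, within a range of 400 nM to 15000 nM.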

Compound 4, half-maximal inhibitory concentration: 11000 nM
The estimate for compound 4 lay 4.4-fold (0.64 log units) below the measured number; measured number inside the range.
By their numbers in this assay, from the lowest: compound 2; then compound 3; then compound 1; then compound 4.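

Taking the carbamoyl unit off the nitrogen on the aromatic ring and putting hexyl there is a large loss in this assay against all three carbamoyl compounds: a 46-fold higher number from compound 3 to compound 4 (1.66 log units; beyond the scatter), a 150-fold higher number from compound 2 to compound 4 (2.18 log units; beyond the scatter) and a 13-fold higher number from compound 1 to compound 4 (1.10 log units; beyond the scatter). Even the ethyl group of compound 1 on the amide-type nitrogen gives a lower number than hexyl directly on the nitrogen on the aromatic ring, so at this position the carbamoyl compounds shown all stand ahead of compound 4. No measurement on hand accounts for this loss.

The change swaps both the carbamoyl unit and the ring for an open chain, and the four compounds do not separate these two differences. Hexylcarbamoyl on this nitrogen would separate them, and a cyclohexyl group placed directly on it would test the ring alone.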